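From 3-chloro-2-fluorophenyl to 3-chloro-4-fluorophenyl

A few compounds are considered here, and "the series" means these few. Any claim that something is new, unique, unknown or untested is made for them only; others in the source may bear on it.

In a functional assay on SK-BR-3 cells (Homo sapiens) for antiproliferative activity, read by MTT assay, with a stated time of 72 h (on this read-out lower numbers stand for stronger inhibition and higher numbers for weaker inhibition), compound 1 (`C=CC(=O)Nc1cc2c(Nc3ccc(OCc4cccc(F)c4)c(Cl)c3)ncnc2cc1OCc1cn(CCCCC(=O)NO)nn1`) gives 16000 nM as a measured number. Compound 2 (`C=CC(=O)Nc1cc2c(Nc3cccc(Cl)c3F)ncnc2cc1OCc1cn(CCCCC(=O)NO)nn1`) stands at > 50000 nM as a limit of the assay, not a number. The change 3-chloro-4-fluorophenyl in place of 3-chloro-2-fluorophenyl on a nitrogen on an aromatic ring leads from compound 2 to compound 3 (`C=CC(=O)Nc1cc2c(Nc3ccc(F)c(Cl)c3)ncnc2cc1OCc1cn(CCCCC(=O)NO)nn1`), which has not yet been measured. In this assay a modest step towards stronger inhibition is expected, resting on compound 1 at 16000 nM as the only numeric anchor. Going by these compounds, the expected step of an at least 2.5-fold lower number from compound 2 to compound 3 (0.39 log units; beyond the scatter) is only an estimate, and its starting point is unknown. For compound 3 the estimated value is 20000 nM with 6000 nM and 50000 nM as the ends of the expected range.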

Compound 3, half-maximal inhibitory concentration: 20000 nM
Estimate against measurement, compound 3: no gap at the digits printed, and the stated range covers the measured number.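

In this assay, 3-chloro-4-fluorophenyl in place of 3-chloro-2-fluorophenyl on the nitrogen gives an at least 2.5-fold lower number from compound 2 to compound 3 (0.39 log units; beyond the scatter), so the change can now be sized, though only from one side. Compound 2 stands at a limit of the assay, not a number: the limit of > 50000 nM in this assay, at which 1 of the 3 values shown sits. Fluoro in place of (3-fluorobenzyl)oxy on an aromatic carbon gives a 1.3-fold higher number from compound 1 to compound 3 (0.10 log units; within the scatter), so that larger group makes no difference beyond the scatter here.

Going by these compounds, the full size of the first step stays open. So does the effect of a 3-chlorophenyl or 3-ethynylphenyl group on the same nitrogen.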